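Fluoro in Place of Hydrogen on a Benzyl Ring

The source may report more compounds than this note shows. Statements on the series, on what has been measured and on what is new or still open speak of the compounds shown alone.

Measured so far:
- compound 1, `Fc1ccc(C[n+]2c[nH]c3ncncc32)cc1`: 4%
- compound 2, `c1ccc(Cc2[nH]cnc3ncnc2-3)cc1`: 1%

In an assay on isolated protein for inhibition of Rho-associated protein kinase 1 (Homo sapiens), tested at 30 uM (on this read-out lower numbers stand for less inhibition and higher numbers for more inhibition at the one concentration tested (going by the name of the read-out)), compound 1 gives 4% and compound 2 gives 1%, the lowest of the two numbers, with compound 1 within the scatter of it. Compound 3, `Fc1ccc(Cc2[nH]cnc3ncnc2-3)cc1`, is not yet measured; it differs from compound 2 by fluoro in place of hydrogen on an aromatic carbon. Within the data shown here, no step between measured compounds is known, and both numbers sit near the floor of the read-out, so the change is expected to stay within the scatter: the step from compound 2 to compound 3 is expected to be a number 2 percentage points higher from compound 2 to compound 3 (within the scatter) in this assay. Compound 3 is therefore estimated at 3%, between -5% and 12%.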

Compound 3, a percentage reported as inhibition, at one concentration (the size of the read-out at that concentration, not a potency): 2%
For compound 3 the middle estimate is 1 percentage points above the measured one, within the range that was stated.
By their numbers in this assay, from the lowest: compounds 2, 3 and 1 (each within the scatter of the next).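

Fluoro in place of hydrogen, on an aromatic carbon para to a large group, gives a number 1 percentage points higher from compound 2 to compound 3 (within the scatter) in this assay and so adds no inhibition that can be told from the scatter. With both compounds near the floor of the read-out, this step cannot show how the position behaves in a compound with clear inhibition. No measurement given here bears on why the step is so small.

Going by these compounds, whether a chloro group, a methoxy group or an amine at this place would raise the inhibition stays open. So does whether fluoro would matter on a compound with a higher number on this read-out.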